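A few compounds are considered here, and "the series" means these few. Any claim that something is new, unique, unknown or untested is made for them only; others in the source may bear on it.

Two compounds sharing one core open this account, compound 1 (`O=Cc1ccc(CO[C@@H]2COc3nc([N+](=O)[O-])cn3C2)cc1`) and compound 2 (`CN(C)C(c1ccc(CO[C@@H]2COc3nc([N+](=O)[O-])cn3C2)cc1)c1nnnn1C(C)(C)C`). In an ADME assay on L6 cells (Rattus norvegicus) for cytotoxicity, read by fluorescence, with a stated time of 72 h (on this read-out lower numbers stand for stronger inhibition and higher numbers for weaker inhibition), compound 1 has no numerical result and stands as "not determined" (no result reported), whereas compound 2 gives 177000 nM. For the measured compounds named here, compound 2 therefore holds the only number available, and it cannot be ranked against any other compound. Going by the values given here, no measured step between closely related compounds exists to show how sensitive this assay is to structural change.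

Compound 3 (`CCN(CC)C(c1ccc(CO[C@@H]2COc3nc([N+](=O)[O-])cn3C2)cc1)c1nnnn1C(C)(C)C`) differs from compound 2 in one place, with diethylamino in place of dimethylamino on a saturated chain carbon bound to two aromatic carbons. With only the value of compound 2, 177000 nM, as a guide, no step beyond the usual scatter is expected in this assay, and any direction is uncertain, though a slightly lower number is expected. The estimated step, a 1.2-fold lower number from compound 2 to compound 3 (0.07 log units; within the scatter), remains within that scatter. The expected value for compound 3 is 150000 nM, within an estimated range of 70000 nM to 300000 nM.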

Compound 3, half-maximal inhibitory concentration: 113000 nM
Beside the measured number, compound 3's estimate is 1.3-fold (0.12 log units) above it, within the range that was stated.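

In this assay, for the compounds shown here, the account now has its only measured step between closely related compounds: diethylamino in place of dimethylamino on a saturated chain carbon bound to two aromatic carbons gives a 1.6-fold lower number from compound 2 to compound 3 (0.19 log units; within the scatter). The earlier compounds shown here could not show how this read-out responds to a structural change, and here the exchange of these two amino groups at this position stays inside the usual scatter of repeated measurements, so the assay does not separate compound 2 from compound 3. No measurement bearing on the reason for this result is available.

From the compounds shown here alone, it remains open whether a ring amine such as morpholine or piperidine, a longer chain such as dipropylamino, or a carboxylic acid on that same saturated chain carbon would produce a step beyond the scatter. A single step at a single place also leaves open how this read-out would respond to changes elsewhere on the shared core, and whether any change there would produce a clearer separation.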